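The source may hold more compounds than are shown below. What is called first, only, known or untested is meant among the compounds shown, and "the series" means these compounds.

Measured so far in a functional assay on HL-60 cells (Homo sapiens) for inhibition, read by CCK-8 assay, with a stated time of 48 h; on this read-out lower numbers stand for stronger inhibition and higher numbers for weaker inhibition:
- compound 1 `CC(=O)Nc1ccc(S(=O)(=O)Oc2cccc(/C=C(\C#N)C(=O)Nc3nnc(-c4cccs4)s3)c2)cc1`: 7940 nM
- compound 2 `COc1ccc(Cc2nnc(NC(=O)/C(C#N)=C/c3ccccc3OS(=O)(=O)c3ccc(OC)cc3)s2)cc1`: 3120 nM
- compound 3 `COc1ccc(S(=O)(=O)Oc2ccccc2/C=C(\C#N)C(=O)Nc2nnc(Cc3cccc4ccccc34)s2)cc1`: 4700 nM

Compound 3 lies within the usual scatter of both other compounds, so these numbers cannot separate it from either one. The next compound, compound 4 `COc1ccc(S(=O)(=O)Oc2ccccc2/C=C(\C#N)C(=O)Nc2nnc(Cc3ccc(F)cc3)s2)cc1`, has not yet been measured in this assay. Its structure differs from that of compound 3 as follows: 4-fluorophenyl in place of naphthalen-1-yl on a saturated chain carbon bound to an aromatic carbon. In words, this is 4-fluorophenyl in place of naphthalen-1-yl on a saturated chain carbon bound to an aromatic carbon.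

For the measured compounds named here, only one measured step bears on this place: a 1.5-fold higher number from compound 2 to compound 3 (0.18 log units; within the scatter), with naphthalen-1-yl in place of 4-methoxyphenyl. Going by the values given here, one small step is thin evidence, and no measured compound carries 4-fluorophenyl. No step beyond the scatter is therefore expected, in either direction. The estimated change is a 1.2-fold lower number from compound 3 to compound 4 (0.09 log units; within the scatter). For compound 4 the expected value is 3800 nM, with an estimated range of 1500 nM to 9500 nM.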

Compound 4, half-maximal inhibitory concentration: 4050 nM
Beside the measured number, compound 4's estimate is 1.1-fold (0.03 log units) below it; low and high end bracket the measured number.
By their numbers in this assay, from the lowest: compounds 2, 4, 3 and 1 (each within the scatter of the next, the first and the last beyond it).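

In this assay the change of naphthalen-1-yl to 4-fluorophenyl on the saturated chain carbon gives a 1.2-fold lower number from compound 3 to compound 4 (0.06 log units; within the scatter) and so leaves the number within the scatter, even with one aromatic ring in place of two. Fluoro in place of methoxy on an aromatic carbon gives a 1.3-fold higher number from compound 2 to compound 4 (0.11 log units; within the scatter) and is also within the scatter, so this read-out cannot separate 4-methoxyphenyl, naphthalen-1-yl and 4-fluorophenyl at this place. Nothing available gives a reason for how close these three numbers lie.

The compounds shown leave open whether any group here can move the number beyond the scatter, since all three groups are aromatic rings without a charge. An amine or a carboxylic acid on the ring, or a cyclohexyl group in place of the ring, could test this.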